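Working notes: benzyloxy in place of nitro

A few compounds are considered here, and "the series" means these few. Any claim that something is new, unique, unknown or untested is made for them only; others in the source may bear on it.

Values in a functional assay on KB cells (Homo sapiens) for antiproliferative activity, read by MTT assay, with a stated time of 72 h; a higher number here means a weaker inhibitor, a lower number a stronger inhibitor:
- Compound 1 `COc1ccc(-c2sc(C(=O)O)cc2-c2cc(OC)c(OC)c(OC)c2)cc1OCc1ccccc1`: > 100000 nM (a limit of the assay)
- Compound 2 `COc1ccc(-c2sccc2-c2cc(OC)c(OC)c(OC)c2)cc1`: 8880 nM
- Compound 3 `COc1ccc(-c2sccc2-c2cc(OC)c(OC)c(OC)c2)cc1[N+](=O)[O-]`: 10600 nM

In this assay, among the compounds with values here, compound 3 lies within the scatter of compound 2, the only other compound with a number. Within the data shown here, compound 1, which also carries benzyloxy, reports only a limit and gives no step.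

Compound 4 `COc1ccc(-c2sccc2-c2cc(OC)c(OC)c(OC)c2)cc1OCc1ccccc1` follows from compound 3 by benzyloxy in place of nitro on an aromatic carbon and so carries benzyloxy in place of nitro on an aromatic carbon, ortho to a methoxy group. Among the measured compounds shown here, one measured step bears on this carbon: nitro in place of hydrogen gives a 1.2-fold higher number from compound 2 to compound 3 (0.08 log units; within the scatter) and stays within the scatter. For the measured compounds named here, no measured step compares benzyloxy with hydrogen or nitro, so the data set no direction, and the range has to stay wide.

No step beyond the scatter is expected in this assay here. The estimated step is a 1.1-fold lower number from compound 3 to compound 4 (0.03 log units; within the scatter) for this change. Compound 4 is estimated at 10000 nM in a expected range of 3000 nM to 40000 nM for now.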

Compound 4, half-maximal inhibitory concentration: > 100000 nM
Compound 4: a limit, no number (the forecaster's own chance of this, stated with the estimate: 15%); at least 10-fold (1.00 log units) between middle value and limit.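

In this assay this aromatic carbon, ortho to a methoxy group, does respond to what it carries, which the earlier pair could not show: nitro in place of hydrogen gave only a 1.2-fold higher number from compound 2 to compound 3 (0.08 log units; within the scatter). Benzyloxy in place of nitro gives an at least 9.4-fold higher number from compound 3 to compound 4 (0.97 log units; beyond the scatter), and benzyloxy in place of hydrogen gives an at least 11-fold higher number from compound 2 to compound 4 (1.05 log units; beyond the scatter). Both new steps rest on a limit of the assay and not on a number, so they mark a minimum size and no exact one: the limit of > 100000 nM in this assay, at which 2 of the 4 values shown sit.

The step between compound 1 and compound 4 cannot be read, as both carry only limits. From the compounds shown here alone, how an amine, a hydroxy group or ethoxy would read on this carbon stays open, so it is not settled which groups here keep the number near those of compound 2 and compound 3.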